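This account rests on a few compounds, and the source may have more. Where it says the series, first, only, none or still open, it means among the compounds named here.

Three compounds share one core and differ only in the group attached to a single aromatic carbon of it. Compound 1 `COc1ccccc1-c1cccc(COc2ccc(S(=O)(=O)CC(=O)O)cc2)c1` carries a 2-methoxyphenyl there, and in a functional assay on CHO cells for agonist activity at Free fatty acid receptor 1 (Homo sapiens), read by FLIPR and calcium flux (a higher number here means that more compound is needed for the effect, a lower number that less compound is needed), compound 1 gives 195 nM. Compound 2 `N#Cc1ccccc1-c1cccc(COc2ccc(S(=O)(=O)CC(=O)O)cc2)c1` carries a 2-cyanophenyl instead, and in this assay compound 2 gives 457 nM. That exchange amounts to a 2.3-fold higher number from compound 1 to compound 2 (0.37 log units; beyond the scatter). Compound 3 `CCOc1ccc(-c2cccc(COc3ccc(S(=O)(=O)CC(=O)O)cc3)c2)c(Cl)c1` carries a 2-chloro-4-ethoxyphenyl, and in this assay compound 3 gives 51.3 nM, the lowest number of the three. The steps that lead into it are a 3.8-fold lower number from compound 1 to compound 3 (0.58 log units; beyond the scatter) and an 8.9-fold lower number from compound 2 to compound 3 (0.95 log units; beyond the scatter).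

Compound 4 `Cc1ccc(C)n1-c1cccc(COc2ccc(S(=O)(=O)CC(=O)O)cc2)c1` has not yet been measured. It differs from compound 3 in one place: 2,5-dimethyl-1H-pyrrol-1-yl in place of 2-chloro-4-ethoxyphenyl on an aromatic carbon. Among the measured compounds shown here, no measured step exchanges a six-membered aromatic ring of carbon only for a five-membered aromatic ring with one hetero atom, so the only guides are the two steps into compound 3, in which each alternative to the 2-chloro-4-ethoxyphenyl gave a higher number beyond the scatter. Compound 4 is therefore expected to need more compound than compound 3, with an estimated step of a 5.8-fold higher number from compound 3 to compound 4 (0.77 log units; beyond the scatter), the direction resting on the values of compound 1 and compound 2 but the size uncertain. The estimate for compound 4 in this assay is 300 nM, within a range from 100 nM to 1000 nM.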

Compound 4, half-maximal effective concentration: 129 nM
Beside the measured number, compound 4's estimate is 2.3-fold (0.37 log units) above it, within the range that was stated.
By their numbers in this assay, from the lowest: compound 3; then compounds 4 and 1 (each within the scatter of the next); then compound 2.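

The position is not limited to a substituted phenyl ring: a 2,5-dimethyl-1H-pyrrol-1-yl, a five-membered aromatic ring with fewer heavy atoms, cannot be told apart from the 2-methoxyphenyl in this assay (a 1.5-fold lower number from compound 1 to compound 4 (0.18 log units; within the scatter)). The same exchange gives a clear gain over the 2-cyanophenyl (a 3.5-fold lower number from compound 2 to compound 4 (0.55 log units; beyond the scatter)) but falls short of the 2-chloro-4-ethoxyphenyl (a 2.5-fold higher number from compound 3 to compound 4 (0.40 log units; beyond the scatter)), so a six-membered ring at this position can lie on either side of the new five-membered ring, and the ring type alone does not set the number. No measurement at hand explains why these groups rank as they do.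

The compounds shown leave open whether the two methyl groups matter, as a plain 1H-pyrrol-1-yl would show, and whether a saturated amine such as piperidin-1-yl would be accepted at the same carbon. They also leave open how much of the low number of the 2-chloro-4-ethoxyphenyl comes from the chlorine and how much from the ethoxy group, which a 2-chlorophenyl and a 4-ethoxyphenyl would separate.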